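A few compounds are considered here, and "the series" means these few. Any claim that something is new, unique, unknown or untested is made for them only; others in the source may bear on it.

Compound 1 `ClCc1ccccc1Cn1cnc2nc(Cl)nc(Cl)c21` was examined in a functional assay on OVCAR-5 cells (Homo sapiens) for cytotoxicity, read by sulforhodamine B assay, with a stated time of 48 h (on this read-out lower numbers stand for stronger inhibition of growth and higher numbers for weaker inhibition of growth), where compound 1 gives 2690 nM. Of the two numbers available it is the lower; its companion, compound 2 `ClCc1ccc(Cn2cnc3c(Cl)nc(Cl)nc32)cc1`, gives 18200 nM in this assay, a higher number whose gap to compound 1 lies beyond the usual scatter. Compound 3 `ClCc1ccccc1Cn1cnc2ncnc(Cl)c21` differs from compound 1 in a single place: hydrogen in place of chloro on an aromatic carbon. For the measured compounds named here, no step between two measured compounds mirrors this change, so the expectation for compound 3 rests on compound 1 alone and is uncertain in direction. The account expects a small weakening, a step of a 1.9-fold higher number from compound 1 to compound 3 (0.27 log units; within the scatter), for compound 3. Compound 3 is therefore estimated at 5000 nM, within the range 1500 nM to 15000 nM, pending the measurement.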

Compound 3, concentration for 50% growth inhibition: 2810 nM
For compound 3 the middle estimate is 1.8-fold (0.25 log units) above the measured one; the measured number falls inside the stated range.
By their numbers in this assay, from the lowest: compounds 1 and 3 (each within the scatter of the next); then compound 2.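

Replacing the chloro group on the aromatic carbon between two ring nitrogen atoms by hydrogen gives a 1.0-fold higher number from compound 1 to compound 3 (0.02 log units; within the scatter) in this assay. Growth inhibition at the level of compound 1 therefore does not depend on this chloro group, which the earlier compounds could not show. Nothing measured here offers an explanation for this result. As far as these compounds go, whether an amine, a methoxy group or a longer chain at this position would be tolerated remains open. From the compounds shown here alone, it is also open whether the same replacement would be tolerated in compound 2.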